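The compounds below may be only part of what the source reports. "The series", "measured", "known", "first", "only" and "open" are said of these compounds alone.

Compound 1 `CCOC(=O)c1cc2c(Cn3ccnc3)c(O)c(OC)cc2nc1C[S+]([O-])c1cccc(OC)c1` has the higher of the two numbers recorded in an ADME assay on HepG2 2.2.15 cells (Homo sapiens) for cytotoxicity, read by MTT assay, with a stated time of 9 days; on this read-out lower numbers stand for higher toxicity in this test and higher numbers for lower toxicity in this test: compound 1 gives 194 uM, while compound 2 `CCOC(=O)c1cc2c(CN3CCCCC3)c(O)c(OC)cc2nc1CSc1ccccc1` gives 60.7 uM, a gap beyond the usual scatter. Compound 3 `CCOC(=O)c1cc2c(Cn3ccnc3)c(O)c(OC)cc2nc1C[S+]([O-])c1ccc(F)cc1` is not yet measured in this assay. It differs from compound 1 in a single place: 4-fluorophenyl in place of 3-methoxyphenyl on a sulfur. For the measured compounds named here, no measured pair shows the effect of this change, so the account expects the step from compound 1 to compound 3 in this assay to be a 1.1-fold lower number from compound 1 to compound 3 (0.06 log units; within the scatter), nothing beyond the scatter. For compound 3 the estimated value is 170 uM, with a range of 70 uM to 400 uM.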

Compound 3, half-maximal toxic concentration: 160 uM
Compound 3: middle estimate off by 1.1-fold (0.03 log units), on the high side, and the stated range covers the measured number.
By their numbers in this assay, from the lowest: compound 2; then compounds 3 and 1 (each within the scatter of the next).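

In this assay, 4-fluorophenyl in place of 3-methoxyphenyl on a sulfur gives a 1.2-fold lower number from compound 1 to compound 3 (0.08 log units; within the scatter). For the compounds shown here, this is the first single-place step available at this sulfur, and it shows that these two aromatic groups can be exchanged there with the values remaining within the scatter of each other. No measurement shown here accounts for this result. The compounds shown leave open whether a group without an aromatic ring, such as an amine or a longer chain, would give a similar number on this sulfur.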